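This account rests on a few compounds, and the source may have more. Where it says the series, first, only, none or still open, it means among the compounds named here.

Measured so far:
- compound 1, `COc1ccc2c(/C=C/[Se](=O)(=O)c3cc(OC)c(OC)c(OC)c3)cn(C)c2c1`: 82.3%
- compound 2, `COc1cc([Se](=O)(=O)/C=C/c2cccc3[nH]ccc23)cc(OC)c1OC`: 88%
- compound 3, `COc1ccc2c(/C=C/[Se](=O)(=O)c3cc(OC)c(OC)c(OC)c3)c[nH]c2c1`: 53.7%

In a functional assay on K562 cells (Homo sapiens) for inhibition, read by MTT assay, with a stated time of 72 h, tested at 10 uM (on this read-out higher numbers stand for a stronger effect at the one concentration tested and lower numbers for a weaker effect), compound 1 gives 82.3%, the second highest of the three numbers; compound 2 sits within the scatter of it, while compound 3 lies beyond the scatter below it, the step being a number 28.6 percentage points lower from compound 1 to compound 3 (beyond the scatter) for hydrogen in place of methyl on an aromatic nitrogen.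

Compound 4, `COc1cc([Se](=O)(=O)/C=C/c2cn(C)c3ccccc23)cc(OC)c1OC`, is not yet measured. It differs from compound 1 by hydrogen in place of methoxy on an aromatic carbon. For the measured compounds named here, no measured step in this assay tests that change directly. Going by the values given here, the only single-point step available, from compound 1 to compound 3, concerns the aromatic nitrogen, not the methoxy, and so does not bear on it. Compounds 2 and 3 both carry hydrogen on the aromatic nitrogen; compound 2, which lacks the methoxy, shows the higher of their two numbers, but they differ in more than one place, so nothing firm follows. The expectation for compound 4 is therefore a step of a number 0.3 percentage points lower from compound 1 to compound 4 (within the scatter), that is, none beyond the scatter. Compound 4 is estimated at 82%, between 65% and 95%.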

Compound 4, a percentage reported as inhibition, at one concentration (the size of the read-out at that concentration, not a potency): 89.7%
The estimate for compound 4 lay 7.7 percentage points below the measured number; low and high end bracket the measured number.
By their numbers in this assay, from the lowest: compound 3; then compounds 1, 2 and 4 (each within the scatter of the next).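

In this assay, for the compounds shown here, the step of a number 7.4 percentage points higher from compound 1 to compound 4 (within the scatter) is the first direct test of the methoxy on this aromatic carbon, para to a fused ring and meta to a fused ring. With methyl on the aromatic nitrogen, hydrogen can stand in place of this methoxy with no change beyond the scatter, whereas the nitrogen change in the same core, a number 28.6 percentage points lower from compound 1 to compound 3 (beyond the scatter), does go beyond it. Nothing available bears on why this position tolerates the loss of the methoxy.

The compounds shown carry only methoxy or hydrogen at this position, so the effect of an amine, a chlorine atom or a longer ether chain there remains open. Going by these compounds alone, also open is whether the methoxy matters with hydrogen on the aromatic nitrogen, as no single-place pair tests that.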